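This account rests on a few compounds, and the source may have more. Where it says the series, first, only, none or still open, it means among the compounds named here.

Measured in a functional assay on HCT-116 cells (Homo sapiens) for inhibition; on this read-out lower numbers stand for stronger inhibition and higher numbers for weaker inhibition:
- compound 1 `CCNC(=O)c1noc(-c2cc(C(C)C)c(O)cc2O)c1-c1cc(COCC(N)=O)no1`: 97 nM
- compound 2 `CCCNCc1cc(-c2c(C(=O)NCC)noc2-c2cc(C(C)C)c(O)cc2O)on1`: 117 nM

Compound 2, at 117 nM, lies within the scatter of compound 1, so the two values cannot be ranked.

The next compound is compound 3 `CCNC(=O)c1noc(-c2cc(C(C)C)c(O)cc2O)c1-c1cc(CNC(C)C)no1`, which has isopropyl in place of propyl on an amine nitrogen. Among the compounds with values here, only one measured step bears on this, a 1.2-fold higher number from compound 1 to compound 2 (0.08 log units; within the scatter). That step brought in the propylamino group and stayed within the scatter. Within the data shown here, no measurement yet compares propyl with isopropyl directly, so the evidence is indirect and the range is kept wide.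

No change beyond the scatter is expected in this assay, and the expected step is a 1.1-fold lower number from compound 2 to compound 3 (0.03 log units; within the scatter). The estimate for compound 3 is 110 nM, with an expected range of 50 nM to 240 nM.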

Compound 3, half-maximal inhibitory concentration: 109 nM
Estimate against measurement, compound 3: 1.0-fold (0.00 log units) above; low and high end bracket the measured number.
By their numbers in this assay, from the lowest: compounds 1, 3 and 2 (each within the scatter of the next).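

In this assay the direct comparison of propyl with isopropyl on the amine nitrogen gives a 1.1-fold lower number from compound 2 to compound 3 (0.03 log units; within the scatter) and so does not separate the straight chain from the branched one. Isopropylamino and carbamoylmethoxy on the saturated chain carbon also cannot be told apart, with a 1.1-fold higher number from compound 1 to compound 3 (0.05 log units; within the scatter) as the step between them, so three different groups at this place now give values that cannot be ranked. No further data on these compounds bear on this flat result.

Still open, on these data alone, is whether a much larger substituent on the amine nitrogen, such as cyclohexyl or benzyl, would give a step beyond the scatter. As far as these compounds go, a carboxylic acid on the saturated chain carbon, in place of the amine, is an equally open case.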